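A few compounds are considered here, and "the series" means these few. Any claim that something is new, unique, unknown or untested is made for them only; others in the source may bear on it.

In a functional assay on MCF7 cells (Homo sapiens) for antiproliferative activity, read by MTT assay, with a stated time of 72 h (a lower number here means a stronger inhibitor, a higher number a weaker inhibitor), compound 1 `COc1cc(-n2ncnc2-c2ccc(C)cc2)cc(OC)c1OC` gives 540 nM. Compound 2 `COc1ccccc1-c1ncnn1-c1cc(OC)c(OC)c(OC)c1` gives > 10000 nM, which is a limit of the assay and not a number. Compound 2 thus stands at the limit of > 10000 nM in this assay, at which 1 of the 2 values shown sits. Compound 3 `COc1cc(-n2ncnc2-c2ccc(SC)cc2)cc(OC)c1OC` differs from it in one place: 4-(methylsulfanyl)phenyl in place of 2-methoxyphenyl on an aromatic carbon. The 2-methoxyphenyl leaves, and a 4-(methylsulfanyl)phenyl enters where compound 1 carries its 4-methylphenyl. For the measured compounds named here, one measured step bears on this change, an at least 18-fold higher number from compound 1 to compound 2 (1.26 log units; beyond the scatter), which is large and beyond the scatter. It brought in the same 2-methoxyphenyl that compound 3 gives up, so a large move to a lower number is expected in this assay, undoing much of that step. The expected size is an at least 20-fold lower number from compound 2 to compound 3 (1.30 log units; beyond the scatter). For compound 3 the estimated value is 500 nM, with an expected range from 100 nM to 3000 nM.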

Compound 3, half-maximal inhibitory concentration: 390 nM
Beside the measured number, compound 3's estimate is 1.3-fold (0.11 log units) above it; the range from low to high includes it.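

In this assay, the 4-(methylsulfanyl)phenyl group restores at this position what the 2-methoxyphenyl group had lost (an at least 25-fold lower number from compound 2 to compound 3 (1.40 log units; beyond the scatter)). The value of compound 2, > 10000 nM, is a limit of the assay and not a number: the limit of > 10000 nM in this assay, at which 1 of the 3 values shown sits. Methylsulfanyl in place of methyl leaves a difference that cannot be told from the scatter (a 1.4-fold lower number from compound 1 to compound 3 (0.14 log units; within the scatter)), so on the evidence of these compounds the position takes either of these two groups on the phenyl ring without a readable change.

The compounds shown do not separate the methoxy group itself from its place on the phenyl ring, and a 4-methoxyphenyl group would bear on that. On these data alone, how an amine or a carboxylic acid on that phenyl ring would read in this assay also stays open.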